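Bis-benzylidene piperidinone fumaramides: amide aryl swap

This account rests on a few compounds, and the source may have more. Where it says the series, first, only, none or still open, it means among the compounds named here.

Measured so far:
compound 1, `Cc1cccc(C)c1NC(=O)/C=C/C(=O)N1C/C(=C\c2ccccc2)C(=O)/C(=C/c2ccccc2)C1`, 7400 nM
compound 2, `O=C(/C=C/C(=O)N1C/C(=C\c2ccc([N+](=O)[O-])cc2)C(=O)/C(=C/c2ccc([N+](=O)[O-])cc2)C1)Nc1ccc([N+](=O)[O-])cc1`, 410 nM

In a functional assay on CCRF-CEM cells (Homo sapiens) for cytotoxicity (on this read-out higher numbers stand for weaker inhibition and lower numbers for stronger inhibition), compound 2 gives 410 nM, the lowest of the two numbers; compound 1 gives 7400 nM, a higher number beyond the usual scatter. Within the data shown here, the two compounds differ at three places at once, so no single step is available.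

Compound 3, `Cc1cccc(C)c1NC(=O)/C=C/C(=O)N1C/C(=C\c2ccc([N+](=O)[O-])cc2)C(=O)/C(=C/c2ccc([N+](=O)[O-])cc2)C1`, keeps the 4-nitrophenyl arms on the core of compound 2 and carries 2,6-dimethylphenyl in place of 4-nitrophenyl on an amide-type nitrogen. Because the gap between 410 nM for compound 2 and 7400 nM for compound 1 cannot be split among the three changed positions, the amide change is taken to account for part of it. A step from compound 2 to compound 3 of moderate size toward a higher number is expected, a 3.7-fold higher number from compound 2 to compound 3 (0.56 log units; beyond the scatter). For compound 3 in this assay the estimate is 1500 nM, expected to fall between 400 nM and 6000 nM.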

Compound 3, half-maximal inhibitory concentration: 230 nM
Beside the measured number, compound 3's estimate is 6.5-fold (0.81 log units) above it, and the stated range ends above it.
By their numbers in this assay, from the lowest: compounds 3 and 2 (each within the scatter of the next); then compound 1.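

On the core carrying the 4-nitrophenyl arms, the amide nitrogen accepts 2,6-dimethylphenyl in place of 4-nitrophenyl with no change beyond the scatter in this assay: the swap gives a 1.8-fold lower number from compound 2 to compound 3 (0.25 log units; within the scatter). Among these compounds, this is the first single-place reading, and it shows that at this position the two aryl groups cannot be told apart on this read-out, although only 4-nitrophenyl carries hydrogen-bond acceptors. Nothing measured here explains why the two groups read alike.

Compound 1 and compound 3 share the amide group but differ at both arms, so the contribution of each arm cannot be read as a single step. Also open, going by these compounds, is whether a phenyl ring bearing an amine or a carboxylic acid on the amide nitrogen would read like these two groups, and whether the same swap holds on the core of compound 1.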